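Moving the Fluorine Around the Phenyl Ring

This account rests on a few compounds, and the source may have more. Where it says the series, first, only, none or still open, it means among the compounds named here.

Compound 1 `O=C(NCc1cc(C(F)(F)F)nn1-c1ccc(C(F)(F)F)cc1)Nc1cccc2[nH]ncc12` gives 3.8 nM in an assay on CHO-K1 cells for antagonist activity at transient receptor potential cation channel subfamily V member 1 (Homo sapiens), read by FLIPR and calcium flux, with a stated time of 6 min; a lower number here means a stronger inhibitor, a higher number a weaker inhibitor.
Compound 2 `Cn1ncc2c(NC(=O)NCc3cc(C(F)(F)F)nn3-c3cccc(F)c3)cccc21` gives 7 nM in this assay.

Within the data shown here, only two compounds have been measured, and they differ in more than one place, so no single step can be read from them. Compound 2 has the higher of the two numbers, but its gap to compound 1 lies within the usual scatter of repeated measurements, so the two values cannot be told apart with confidence.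

Compound 3 `Cn1ncc2c(NC(=O)NCc3cc(C(F)(F)F)nn3-c3ccc(F)cc3)cccc21` is the next compound, not yet measured. It keeps everything in compound 2 except the position of one fluorine: 4-fluorophenyl in place of 3-fluorophenyl on an aromatic nitrogen. The atoms stay the same; only where the fluorine sits on the phenyl ring changes.

Among the measured compounds shown here, with no measured step of this kind available, the expectation rests on how close the two measured compounds already are. Compound 3 is expected to show a small step, no change at the digits printed from compound 2 to compound 3 (within the scatter), not beyond the scatter in either direction. Compound 3 is therefore estimated at 7 nM in this assay, with a likely range from 2.5 nM to 20 nM.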

Compound 3, inhibition constant: 8.4 nM
Estimate against measurement, compound 3: 1.2-fold (0.08 log units) below; the measured number falls inside the stated range.
By their numbers in this assay, from the lowest: compounds 1, 2 and 3 (each within the scatter of the next, the first and the last beyond it).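

Among these compounds, this is the first pair that differs in one place only, and in this assay it gives a 1.2-fold higher number from compound 2 to compound 3 (0.08 log units; within the scatter). On this aromatic nitrogen, then, 3-fluorophenyl and 4-fluorophenyl cannot be told apart: moving the fluorine between these two places on the phenyl ring produces no difference that can be separated from the ordinary spread of repeated measurements. Nothing on hand speaks to why the two compounds read alike, so the pair records a result without offering an explanation for it.

From the compounds shown here alone, whether the phenyl ring accepts something other than a single fluorine remains open, since a chlorine, a methoxy group or an amine at either place would test much more than this shift of one atom does. Among the compounds shown here, compound 1 differs from compound 2 and compound 3 in more than one place, so no step to it can be read, and the effect of the methyl group on the core cannot be separated from that of the trifluoromethyl group on the phenyl ring.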